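Chalcone series on colon carcinoma cells: two ring swaps

A few compounds are considered here, and "the series" means these few. Any claim that something is new, unique, unknown or untested is made for them only; others in the source may bear on it.

Of the compounds shown here, three of one series have been measured in a functional assay on HCT-116 cells (Homo sapiens) for inhibition, read by sulforhodamine B assay, with a stated time of 72 h; a higher number here means a weaker inhibitor, a lower number a stronger inhibitor. Compound 1 `COc1ccc(C(=O)/C=C/c2cn(-c3ccccc3)nc2-c2ccsc2)cc1OC` gives 1600 nM. Compound 2 `COc1ccc(OC)c(C(=O)/C=C/c2cn(-c3ccccc3)nc2-c2ccsc2)c1` gives 3400 nM. Compound 3 `COc1ccc(C(=O)/C=C/c2cn(-c3ccccc3)nc2-c2ccncc2)cc1OC` gives 1200 nM. Compound 4 `COc1ccc(OC)c(C(=O)/C=C/c2cn(-c3ccccc3)nc2-c2ccncc2)c1` has not been measured yet.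

Compound 1 and compound 2 differ by 2,5-dimethoxyphenyl in place of 3,4-dimethoxyphenyl on a carbonyl carbon; this change made a step of a 2.1-fold higher number from compound 1 to compound 2 (0.33 log units; beyond the scatter). Compound 1 and compound 3 differ by pyridin-4-yl in place of thiophen-3-yl on an aromatic carbon; the step of a 1.3-fold lower number from compound 1 to compound 3 (0.12 log units; within the scatter) is small and within the scatter, so compound 1 and compound 3 cannot be ordered. Compound 3 sits at the lowest of the three numbers, but only its gap to compound 2 is beyond the scatter, so it is not called the strongest of the set.

Compound 3 and compound 4 differ by 2,5-dimethoxyphenyl in place of 3,4-dimethoxyphenyl on a carbonyl carbon. The same kind of change carried compound 1 to compound 2; the place line is the same word for word in both cases, so the surroundings of the change are the same, while the cores differ by pyridin-4-yl in place of thiophen-3-yl on an aromatic carbon. Among the compounds with values here, because the earlier step of a 2.1-fold higher number from compound 1 to compound 2 (0.33 log units; beyond the scatter) was modest and beyond the scatter, a step of similar size and direction is expected for compound 4, namely a 2.1-fold higher number from compound 3 to compound 4 (0.32 log units; beyond the scatter), with some widening of the range because only one earlier instance is known. For compound 4 in this assay the estimate is 2500 nM, expected to lie between 1200 nM and 5500 nM.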

Compound 4, half-maximal inhibitory concentration: 900 nM
For compound 4 the middle estimate is 2.8-fold (0.44 log units) above the measured one; measured number outside the range, below it.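

In this series the change to 2,5-dimethoxyphenyl in place of 3,4-dimethoxyphenyl on a carbonyl carbon did not carry over from one core to the other in this assay: on the second core the step is a 1.3-fold lower number from compound 3 to compound 4 (0.12 log units; within the scatter), so no order can be given for that pair, and the two steps differ: the same change on two cores in this assay, a 2.1-fold higher number (0.33 log units; beyond the scatter) from compound 1 to compound 2 and a 1.3-fold lower number (0.12 log units; within the scatter) from compound 3 to compound 4, 2.8-fold (0.45 log units) apart, beyond the scatter of two such steps. The swap to pyridin-4-yl in place of thiophen-3-yl on an aromatic carbon, which could not be read on the first core, gives a clear step on the 2,5-dimethoxyphenyl core, a 3.8-fold lower number from compound 2 to compound 4 (0.58 log units; beyond the scatter), and this too differs from its earlier instance: the same change on two cores in this assay, a 1.3-fold lower number (0.12 log units; within the scatter) from compound 1 to compound 3 and a 3.8-fold lower number (0.58 log units; beyond the scatter) from compound 2 to compound 4, 2.8-fold (0.45 log units) apart, beyond the scatter of two such steps. These two gaps are a single result seen from two sides, resting on four compounds, and they show only that the size of each change here depends on what else the compound carries; they give no reason for this and no rule for other cores.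

As far as these compounds go, it remains open whether the dependence holds when an amine or a carboxylic acid stands in place of thiophen-3-yl or pyridin-4-yl on that aromatic carbon. From the compounds shown here alone, it is equally open how a single methoxy group on the ring at the carbonyl carbon would behave on either core in this assay.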